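Removing a Methoxy Group: What Microsomal Stability to Expect

The source may report more compounds than this note shows. Statements on the series, on what has been measured and on what is new or still open speak of the compounds shown alone.

Compound 1 `COc1ccc(-c2cc([C@@H](O)C[C@@H](O)CCc3ccc(Cl)cc3)no2)cc1` and compound 2 `COc1ccc(CC[C@H](O)C[C@H](O)c2cc(-c3ccc(OC)cc3)on2)cc1` share the same core and differ only by methoxy in place of chloro on an aromatic carbon. In an ADME assay on microsomes from liver (Homo sapiens) for metabolic stability, read by LC-MS, using NADPH, with stated times of 5 min and 30 min, tested at 1 uM (a lower number here means that less of the compound is left, a higher number that more of the compound is left), compound 1 gives < 20%, which is a limit of the assay and not a number. In this assay compound 2 likewise gives < 20%, again a limit. The step that the two limits leave unreadable from compound 1 to compound 2 cannot be sized because of the limit of < 20% in this assay, at which 2 of the 2 values shown sit. For the measured compounds named here, compound 2 therefore stands at a limit of the assay, and so does the one other compound measured.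

Compound 3 `COc1ccc(CC[C@H](O)C[C@H](O)c2cc(-c3ccccc3)on2)cc1` differs from compound 2 by hydrogen in place of methoxy on an aromatic carbon. Going by the values given here, no measured step bears directly on this change; the only one available, a step that the two limits leave unreadable from compound 1 to compound 2, is unreadable because of the limit of < 20% in this assay, at which 2 of the 2 values shown sit. With every known value sitting at the limit, the expectation is that compound 3 stays close to it, and the step that the limit leaves unreadable from compound 2 to compound 3 is estimated to be small. Compound 3 is estimated at 15% in this assay, with a range from 5% to 30%.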

Compound 3, percent of the compound remaining in the Homo sapiens assay: 33%
For compound 3 the middle estimate is 18 percentage points below the measured one; measured number outside the range, above it.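

For the compounds shown here, in the Homo sapiens assay the change from 4-methoxyphenyl to phenyl gives the first step in these compounds that can be read, a number at least 13 percentage points higher from compound 2 to compound 3 (beyond the scatter), whereas the step from chloro to methoxy stayed unreadable. On these data alone, this shows that the methoxy on this aromatic carbon, para to a large group, is a place where a single change lifts the compound clear of the limit, though the step has only a lower bound and its full size stays unknown: the limit of < 20% in the Homo sapiens assay, at which 2 of the 3 values shown sit. In a physicochemical assay for solubility, in phosphate buffer, measured as kinetic solubility, at pH 7.4 (on this read-out higher numbers stand for higher solubility and lower numbers for lower solubility), compound 2 gives 12000 nM and compound 3 gives 25000 nM, so the same change also goes with higher solubility and here the two read-outs rise together: the measured solubility of compound 2, 12000 nM, and of compound 3, 25000 nM, a 2.1-fold higher number (0.32 log units; beyond the scatter).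

The compounds shown leave open whether the gain in the Homo sapiens assay depends on the loss of the methoxy itself, or whether a fluorine atom, a trifluoromethyl or a nitrile at this place would give a similar result. They also leave open whether replacing the remaining methoxy of compound 3 with hydrogen or a fluorine atom would give a further step in the same direction.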